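Shortening a Propyl Amide While Cytotoxicity Stays Silent

The source may hold more compounds than are shown below. What is called first, only, known or untested is meant among the compounds shown, and "the series" means these compounds.

Measured compounds:
compound 1 `O=[N+]([O-])c1ccc(Sc2cn(-c3ccc4c(c3)B(O)OC4)c3ccccc23)cc1`: > 10 ug/mL
compound 2 `CCCNC(=O)c1cccn1-c1ccc2c(c1)B(O)OC2`: > 10 ug/mL

In an ADME assay on L929 cells (Mus musculus) for cytotoxicity, read by resazurin assay, with a stated time of 72 h (on this read-out higher numbers stand for weaker inhibition and lower numbers for stronger inhibition), compound 1 gives only a limit, > 10 ug/mL. In this assay compound 2 also gives only a limit, > 10 ug/mL. Both readings sit at the limit of > 10 ug/mL in this assay, at which 2 of the 2 values shown sit, and compound 2 stands exactly where every value shown stands, with no finished number placing it. Compound 3 `CNC(=O)c1cccn1-c1ccc2c(c1)B(O)OC2` differs from compound 2 by hydrogen in place of ethyl on a saturated chain carbon bound to an amide-type nitrogen. For the measured compounds named here, no measured step exists for this change. The shortening is expected to leave the read-out at the limit, with no step beyond the usual scatter. The step that the limit leaves unreadable from compound 2 to compound 3 is expected to be small. Compound 3 is estimated at 15 ug/mL, between 5 ug/mL and 50 ug/mL.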

Compound 3, half-maximal inhibitory concentration: > 10 ug/mL
Compound 3: only a limit was reported; the forecaster's own chance of this, stated with the estimate: 85%; the middle value does not contradict the limit.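

For the compounds shown here, compound 2 and compound 3 each give only a limit, and no step from the propyl to the methyl amide can be read between them. The compounds shown leave open the concentration at which any of them would reach half-maximal inhibition in this assay.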